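Thiophen-3-yl in place of thiophen-2-yl on the shared core

This account rests on a few compounds, and the source may have more. Where it says the series, first, only, none or still open, it means among the compounds named here.

Compound 1 `Oc1cccc(-c2cc(-c3ccccc3)cc(-c3ccccc3)n2)c1` gives 0% in an assay on isolated protein for inhibition of DNA topoisomerase 1 (Homo sapiens), with a stated time of 30 min, tested at 20 uM; a higher number here means a stronger effect of the compound at the concentration tested, a lower number a weaker effect. Within the data shown here, compound 2 `Oc1cccc(-c2cc(-c3ccccc3)cc(-c3cccs3)n2)c1` gives 5.8% in this assay, the higher of the two numbers so far, though the step of a number 5.8 percentage points higher from compound 1 to compound 2 (within the scatter) sits within the scatter. Compound 3 `Oc1cccc(-c2cc(-c3ccccc3)cc(-c3ccsc3)n2)c1` differs from compound 2 by thiophen-3-yl in place of thiophen-2-yl on an aromatic carbon. Among the measured compounds shown here, the only step available for comparison, a number 5.8 percentage points higher from compound 1 to compound 2 (within the scatter), changed the same position without a shift beyond the scatter, so no step beyond the scatter is expected in this assay here either. Compound 3 is therefore estimated at 5%, within 0% to 15%. The expected step is a number 0.8 percentage points lower from compound 2 to compound 3 (within the scatter).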

Compound 3, a percentage reported as inhibition, at one concentration (the size of the read-out at that concentration, not a potency): 6.8%
Estimate against measurement, compound 3: 1.8 percentage points below, and the stated range covers the measured number.
By their numbers in this assay, from the lowest: compounds 1, 2 and 3 (each within the scatter of the next).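

Thiophen-3-yl and thiophen-2-yl on this carbon next to the ring nitrogen cannot be told apart in this assay, the step being a number 1 percentage points higher from compound 2 to compound 3 (within the scatter). Thiophen-3-yl also cannot be told apart from phenyl here, with a number 6.8 percentage points higher from compound 1 to compound 3 (within the scatter), so neither thiophene attachment separates from phenyl at this position. No evidence at hand accounts for these numbers.

Going by these compounds, whether any group at this position gives a step beyond the scatter remains open. An amine, a carboxylic acid or a longer chain on this carbon would test that.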